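Methyl for Benzyl on Selenium: Expected Growth Inhibition

The compounds below may be only part of what the source reports. "The series", "measured", "known", "first", "only" and "open" are said of these compounds alone.

Three compounds have been measured in a functional assay on HepG2 cells (Homo sapiens) for cytotoxicity, read by MTT assay, with a stated time of 72 h; on this read-out lower numbers stand for stronger inhibition of growth and higher numbers for weaker inhibition of growth:

Compound 1, `C[Se]/C(=N\C(=O)c1ccco1)NC(=O)c1ccco1`: 760 nM
Compound 2, `O=C(/N=C(/NC(=O)c1ccco1)[Se]Cc1ccccc1)c1ccco1`: 7650 nM
Compound 3, `O=C(/N=C(/NC(=O)c1csc([N+](=O)[O-])c1)[Se]Cc1ccccc1)c1csc([N+](=O)[O-])c1`: 34100 nM

Compound 1 and compound 2 share one core and differ only in the group on selenium: hydrogen in place of phenyl on a saturated chain carbon bound to a selenium atom. That single change gives a 10-fold lower number from compound 2 to compound 1 (1.00 log units; beyond the scatter). Compound 3 carries a different core; how its core differs from that of compound 2 is not broken down here. Among the three, compound 3 gives the highest number in this assay, its steps to compound 2 and to compound 1 both lying beyond the scatter.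

Compound 4, `C[Se]/C(=N\C(=O)c1csc([N+](=O)[O-])c1)NC(=O)c1csc([N+](=O)[O-])c1`, has not yet been measured. It relates to compound 3 exactly as compound 1 relates to compound 2: hydrogen in place of phenyl on a saturated chain carbon bound to a selenium atom. The place of the change is the same in both pairs, so it is the same change on a different core. Among the measured compounds shown here, because the earlier pair showed a 10-fold lower number from compound 2 to compound 1 (1.00 log units; beyond the scatter), the step expected here is of similar size, a 10-fold lower number from compound 3 to compound 4 (1.00 log units; beyond the scatter), though only one prior example supports this. Compound 4 is therefore expected to give about 3400 nM in this assay, with a plausible range from 1200 nM to 9500 nM.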

Compound 4, concentration for 50% growth inhibition: 620 nM
For compound 4 the middle estimate is 5.5-fold (0.74 log units) above the measured one; the measured number lies below the stated range.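

In this assay, the change from benzyl to methyl on selenium acts in the same direction on the second core, giving a 55-fold lower number from compound 3 to compound 4 (1.74 log units; beyond the scatter). Among the compounds shown here, the direction of the change thus carries across the two cores, while its size does not: the same change on two cores in this assay, a 10-fold lower number (1.00 log units; beyond the scatter) from compound 2 to compound 1 and a 55-fold lower number (1.74 log units; beyond the scatter) from compound 3 to compound 4, 5.5-fold (0.74 log units) apart, beyond the scatter of two such steps With only two pairs, this does not show how large the step would be on any further core, and the values alone do not explain why the two steps differ.

Among the compounds shown, only methyl and benzyl stand on selenium, so it remains open whether an ethyl group, a longer chain or a chain ending in an amine would give steps of the same direction on both cores. Going by these compounds, it also remains open whether the two cores would respond in the same way with a sulfur atom in place of selenium.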